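This account rests on a few compounds, and the source may have more. Where it says the series, first, only, none or still open, it means among the compounds named here.

In a functional assay on HeLa cells (Homo sapiens) for cytotoxicity (on this read-out lower numbers stand for stronger inhibition and higher numbers for weaker inhibition), compound 1 (`C/C=C/C(=O)OC1=CC(=O)c2ccccc2C1=O`) reads 37900 nM and compound 3 (`O=C1C=CC(=O)c2c(Oc3cccs3)cccc21`) reads 5210 nM on the same scale. Compound 2 (`Cc1ccc(S(=O)(=O)Oc2ccc3c(c2)C(=O)C=CC3=O)cc1`) reads 15100 nM and is second highest of the three, with compound 1 and compound 3 both beyond the scatter from it. Compound 4 (`CS(=O)(=O)Oc1ccc2c(c1)C(=O)C=CC2=O`) has methyl in place of 4-methylphenyl on a sulfonyl sulfur. Among the compounds with values here, no measured pair differs in one place only, so no step gives direct guidance. Within the data shown here, the only guide is the band of measured values, with compound 3 at its low end at 5210 nM and compound 1 at its high end at 37900 nM. In this assay the expected step (a 1.2-fold higher number from compound 2 to compound 4 (0.08 log units; within the scatter)) is none beyond the scatter, in either direction. For compound 4 the expected value is 18000 nM within an estimated range (6000 nM to 50000 nM).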

Compound 4, half-maximal inhibitory concentration: 17700 nM
Estimate against measurement, compound 4: 1.0-fold (0.01 log units) above, and the stated range covers the measured number.
By their numbers in this assay, from the lowest: compound 3; then compounds 2 and 4 (each within the scatter of the next); then compound 1.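

In this assay, within the data shown here, the change on the sulfonyl sulfur gives the first direct comparison: a 1.2-fold higher number from compound 2 to compound 4 (0.07 log units; within the scatter). Methyl and 4-methylphenyl cannot be told apart at this place, so the six-membered aromatic ring of 4-methylphenyl is not required there for this read-out. No measurement on hand explains this result.

Still open, as far as these compounds go, is whether a longer alkyl chain, or an amine-bearing chain, on the sulfonyl sulfur would also stay within the scatter. Also open, from the compounds shown here alone, is whether replacing the sulfonyl link with a carboxylic ester would do so on this same core.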